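Returning a piperidine to the oxadiazole carbon

This account rests on a few compounds, and the source may have more. Where it says the series, first, only, none or still open, it means among the compounds named here.

Measured so far in an assay on HeLa cells for inhibition of sphingosine-1-phosphate transporter SPNS2 (Mus musculus), read by LC-MS, tested at 2 uM; a higher number here means more inhibition at the concentration tested (going by the name of the read-out), a lower number less inhibition: compound 1 `CCCCCCCCCCc1ccc(-c2noc(C3CCNCC3)n2)cc1` gives 66%; compound 2 `CCCCCCCCCCc1ccc(-c2noc(-c3cccc(CN)c3)n2)cc1` gives 2%.

Compound 2 stands lowest of the two numbers. Compound 3 `CCCCCCCCCCc1ccc(-c2noc(CCCN3CCCCC3)n2)cc1` differs from compound 2 by 3-(piperidin-1-yl)propyl in place of 3-(aminomethyl)phenyl on an aromatic carbon. Among the compounds with values here, the only measured step bears on it directly: a number 64 percentage points lower from compound 1 to compound 2 (beyond the scatter), where the piperidin-4-yl group left the same aromatic carbon. Compound 3 brings a piperidine ring back there, though as 3-(piperidin-1-yl)propyl, so a rise in this assay beyond the scatter is expected, though not necessarily the whole way. Compound 3 is therefore expected to give about 40%, within 10% to 70%. That estimate means an expected step of a number 38 percentage points higher from compound 2 to compound 3 (beyond the scatter).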

Compound 3, a percentage reported as inhibition, at one concentration (the size of the read-out at that concentration, not a potency): 0%
Estimate against measurement, compound 3: 40 percentage points above; measured number outside the range, below it.
By their numbers in this assay, from the lowest: compounds 3 and 2 (each within the scatter of the next); then compound 1.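

In this assay, a piperidine ring at this position does not by itself restore the reading: 3-(piperidin-1-yl)propyl in place of piperidin-4-yl gives a number 66 percentage points lower from compound 1 to compound 3 (beyond the scatter) in the same setting. Against 3-(aminomethyl)phenyl, the same group gives a number 2 percentage points lower from compound 2 to compound 3 (within the scatter) and so cannot be told apart from it here. No evidence available accounts for this result.

Still open, going by these compounds, is whether a shorter link, such as a piperidin-4-ylmethyl group, would stand with compound 1 or with compound 3. The same question holds for a pyrrolidine or a piperazine on this carbon.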